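Swapping a Fluoropyridyl for a Chloropyridinone: Permeability Outlook

The source may hold more compounds than are shown below. What is called first, only, known or untested is meant among the compounds shown, and "the series" means these compounds.

Three analogues sharing one core have been measured in an ADME assay for permeability, using PAMPA, at pH 5.5; a lower number here means that the compound crosses the layer more slowly, a higher number that the compound crosses the layer faster. Compound 1 `CCCCc1nc(=O)c(S(=O)(=O)c2ccc(-c3ccnc(NC(=O)C4CC4)c3)cc2)c(O)n1-c1c(OC)cccc1OC` gives 183 nm/s, compound 2 `CCCCc1nc(=O)c(S(=O)(=O)c2ccc(-c3ccc(F)cc3)cc2)c(O)n1-c1c(OC)cccc1OC` gives 418 nm/s, and compound 3 `CCCCc1nc(=O)c(S(=O)(=O)c2ccc(-c3ccc(F)nc3)cc2)c(O)n1-c1c(OC)cccc1OC` gives 516 nm/s. Compound 3 thus sits at the upper end of the three numbers; its separation from compound 1 is beyond the scatter, while compound 2 and compound 3 cannot be told apart. The measured steps are a 2.3-fold higher number from compound 1 to compound 2 (0.36 log units; beyond the scatter), a 2.8-fold higher number from compound 1 to compound 3 (0.45 log units; beyond the scatter) and a 1.2-fold higher number from compound 2 to compound 3 (0.09 log units; within the scatter). The unmeasured compound 4 `CCCCc1nc(=O)c(S(=O)(=O)c2ccc(-n3cc(Cl)ccc3=O)cc2)c(O)n1-c1c(OC)cccc1OC` differs from compound 3 by a group of 8 heavy atoms (5 carbon, 1 nitrogen, 1 oxygen, 1 chlorine; one six-membered aromatic ring with 1 hetero atom) in place of a group of 7 heavy atoms (5 carbon, 1 nitrogen, 1 fluorine; one six-membered aromatic ring with 1 hetero atom), on an aromatic carbon. Among the measured compounds shown here, no measured pair shows this exact exchange. Since a 2.3-fold higher number from compound 1 to compound 2 (0.36 log units; beyond the scatter) and a 2.8-fold higher number from compound 1 to compound 3 (0.45 log units; beyond the scatter) both removed a carbonyl-bearing group and ran upward, whereas a 1.2-fold higher number from compound 2 to compound 3 (0.09 log units; within the scatter) exchanged one fluorinated ring for another and stayed within the scatter, and the group entering compound 4 brings a carbonyl back, a modest downward step is expected, a 2.1-fold lower number from compound 3 to compound 4 (0.31 log units; beyond the scatter). Compound 4 is therefore estimated at 250 nm/s, with a range from 120 nm/s to 450 nm/s.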

Compound 4, apparent permeability: 83 nm/s
Beside the measured number, compound 4's estimate is 3.0-fold (0.48 log units) above it, outside the stated range (below it).
By their numbers in this assay, from the lowest: compound 4; then compound 1; then compounds 2 and 3 (each within the scatter of the next).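

In this assay, the group entering on this aromatic carbon, para to a large group, brings a 6.2-fold lower number from compound 3 to compound 4 (0.79 log units; beyond the scatter) and also a 5.0-fold lower number from compound 2 to compound 4 (0.70 log units; beyond the scatter) as steps wider than any among the earlier three compounds, so this place is not as indifferent to its ring as the tie between compound 2 and compound 3 had suggested. The new group also sits under the larger group of compound 1, giving a 2.2-fold lower number from compound 1 to compound 4 (0.34 log units; beyond the scatter) even though the heavy atoms fall in number, so across these four compounds the number does not follow group size. Nothing available here accounts for the fall.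

The entering group brings its oxygen and its chlorine together, so the compounds shown leave open which of the two goes with the fall. Also open, going by these compounds, is how the same ring would read with a methyl or a bromine in place of the chlorine.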